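Solubility of a fluoronaphthyl pyridinone series in phosphate buffer

This account rests on a few compounds, and the source may have more. Where it says the series, first, only, none or still open, it means among the compounds named here.

Measured compounds:
compound 1 `C/C(=C1/OC(=O)NC1=O)C(c1ccc(-c2ccc3cccc(F)c3c2)[nH]c1=O)C(C)C`: 17200 nM
compound 2 `Cc1cc(C(/C=C2\OC(=O)NC2=O)C(C)C)c(=O)[nH]c1-c1ccc2cccc(F)c2c1`: 35700 nM
compound 3 `CC(C)[C@@H](c1ccc(-c2ccc3cccc(F)c3c2)[nH]c1=O)[C@H]1OC(=O)NC1=O`: 31600 nM

Of the compounds shown here, three sharing the same core have been measured in a physicochemical assay for solubility, in phosphate buffer, measured as kinetic solubility; a higher number here means a more soluble compound, a lower number a less soluble compound. Compound 1 gives 17200 nM, the lowest of the three numbers. Compound 3 gives 31600 nM, and the gap between compound 1 and compound 3 lies within the usual scatter of this assay, so no order between them can be claimed. Compound 2 gives 35700 nM, a gap to compound 1 that lies just beyond the scatter.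

Compound 4 `CC(C)C(c1ccc(-c2ccc3cccc(F)c3c2)[nH]c1=O)C1C(=O)NC(=O)N1C` has not yet been measured. It differs from compound 1 in one place: a group of 8 heavy atoms (4 carbon, 2 nitrogen, 2 oxygen; one five-membered non-aromatic ring with 2 hetero atoms) in place of a group of 9 heavy atoms (5 carbon, 1 nitrogen, 3 oxygen; one five-membered non-aromatic ring with 2 hetero atoms), on a saturated chain carbon bound to an aromatic carbon and a saturated chain carbon. Among the compounds with values here, no step between measured compounds matches this change, so no measured size can be borrowed for it.

The expectation for compound 4 therefore rests on the spread of the three measured numbers alone. Since compound 3 already gives 31600 nM with the ring attached in the same way on the chain, the step from compound 1 to compound 4 is expected to be small, a 1.6-fold higher number from compound 1 to compound 4 (0.21 log units; within the scatter), and quite possibly within the scatter. The estimate for compound 4 in this assay is 28000 nM, with a range from 11000 nM to 70000 nM.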

Compound 4, solubility: 17900 nM
Compound 4: the middle estimate sits 1.6-fold (0.19 log units) above what was measured; measured number inside the range.
By their numbers in this assay, from the lowest: compounds 1, 4, 3 and 2 (each within the scatter of the next, the first and the last beyond it).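

In this assay, putting 3-methyl-2,5-dioxoimidazolidin-4-yl in place of the group on the saturated chain carbon bound to an aromatic carbon and a saturated chain carbon gives a 1.0-fold higher number from compound 1 to compound 4 (0.02 log units; within the scatter), the only one-place comparison among the compounds shown. At this place, then, the read-out does not separate the two five-membered non-aromatic rings, even though they differ in their heavy atoms, their hydrogen-bond acceptors and their double bonds outside aromatic rings. No independent measurement on either group bears on this result, so it stands as an observation without an explanation.

This single step cannot show whether the same holds for a group of another kind on this carbon, such as a carboxylic acid or an amine, or for the same ring carrying an ethyl in place of its methyl. It also cannot show whether the exchange would read the same way on a compound that differs from compound 1 elsewhere in its structure.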